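The source may report more compounds than this note shows. Statements on the series, on what has been measured and on what is new or still open speak of the compounds shown alone.

Working notes on the series: in a functional assay (plasma) with Oryctolagus cuniculus as the target (a higher number here means a weaker inhibitor, a lower number a stronger inhibitor), compound 1 `Cc1nc2cnccc2n1CC1CCN(C(=O)CNC(c2ccccc2)c2ccccc2)CC1` gives 13 nM and compound 2 `COC(=O)NC(CC(=O)N1CCC(Cn2c(C)nc3cnccc32)CC1)c1ccccc1` gives 12 nM as the only other number so far. These two values lie within the scatter of each other, so compound 2 stands together with compound 1 on the present numbers. Compound 3 `Cc1nc2cnccc2n1CC1CCN(C(=O)CCc2ccccc2)CC1` differs from compound 2 by one change, (hydrogen in place of (methoxycarbonyl)amino on a saturated chain carbon bound to an aromatic carbon and a saturated chain carbon), with hydrogen in place of (methoxycarbonyl)amino on a saturated chain carbon bound to an aromatic carbon and a saturated chain carbon. Among the compounds with values here, no measured pair shows this change, so the size of the step remains a judgement. A moderate rise in this assay is expected, towards a weaker inhibitor, although a step within the scatter cannot be excluded. The expected change is a 3.3-fold higher number from compound 2 to compound 3 (0.52 log units; beyond the scatter) as an estimate only. Compound 3 is estimated at 40 nM with an expected range from 10 nM to 160 nM for this measurement.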

Compound 3, half-maximal inhibitory concentration: 60 nM
Compound 3: middle estimate off by 1.5-fold (0.18 log units), on the low side; measured number inside the range.
By their numbers in this assay, from the lowest: compounds 2 and 1 (each within the scatter of the next); then compound 3.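

In this assay, within the data shown here, hydrogen in place of (methoxycarbonyl)amino on a saturated chain carbon bound to an aromatic carbon and a saturated chain carbon gives a 5.0-fold higher number from compound 2 to compound 3 (0.70 log units; beyond the scatter) and so provides the first measured step at this position, beyond the scatter and towards a weaker inhibitor. The step is modest, and compound 3 still gives 60 nM without the group, so the group is not required for a measurable number. Nothing available here accounts for the size of this step.

As far as these compounds go, whether the step depends on the whole (methoxycarbonyl)amino group or only part of it stays open; a free amine, an acetamide or a hydroxyl on the same carbon would separate these. Also open, from the compounds shown here alone, is whether a carboxylic acid or a longer chain at this place would raise or lower the number.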